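A few compounds are considered here, and "the series" means these few. Any claim that something is new, unique, unknown or untested is made for them only; others in the source may bear on it.

Working notes on the series. Three measured compounds share one core and differ only in the group on the saturated chain carbon bound to a sulfur. Compound 1 `O=C(CSc1nnc(Br)n1Cc1ccc(Br)c2ccccc12)NO` carries hydroxycarbamoyl there; in an assay on HEK293 cells for inhibition of solute carrier family 22 member 12 (Homo sapiens) (on this read-out higher numbers stand for weaker inhibition and lower numbers for stronger inhibition), compound 1 gives 640 nM. Compound 2 `O=S(=O)(O)CSc1nnc(Br)n1Cc1ccc(Br)c2ccccc12` carries sulfo, and in this assay compound 2 gives 14400 nM. Compound 3 `O=S(=O)(CSc1nnc(Br)n1Cc1ccc(Br)c2ccccc12)Nc1ccccc1` carries phenylsulfamoyl, and in this assay compound 3 gives 15800 nM. The steps are a 23-fold higher number from compound 1 to compound 2 (1.35 log units; beyond the scatter), a 25-fold higher number from compound 1 to compound 3 (1.39 log units; beyond the scatter) and a 1.1-fold higher number from compound 2 to compound 3 (0.04 log units; within the scatter). Compound 2 thus holds the second highest of the three numbers, sits within the scatter of compound 3 and stands far from compound 1.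

Compound 4 `O=S(=O)(CSc1nnc(Br)n1Cc1ccc(Br)c2ccccc12)Nc1cncc(C(F)(F)F)c1` is not yet measured. Against compound 2 the change is (5-(trifluoromethyl)pyridin-3-yl)amino in place of hydroxy on a sulfonyl sulfur. Going by the values given here, the one measured step at the same place, a 1.1-fold higher number from compound 2 to compound 3 (0.04 log units; within the scatter), exchanged hydroxy on the sulfonyl sulfur for anilino and stayed within the scatter; the steps from compound 1 concern the other position and do not bear on this exchange. On that basis no step beyond the scatter is expected in this assay, with a 1.0-fold higher number from compound 2 to compound 4 (0.02 log units; within the scatter) as the estimated step. Compound 4 is therefore expected to give about 15000 nM, estimated to fall between 6000 nM and 40000 nM.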

Compound 4, half-maximal inhibitory concentration: 6380 nM
Beside the measured number, compound 4's estimate is 2.4-fold (0.37 log units) above it; the measured number falls inside the stated range.
By their numbers in this assay, from the lowest: compound 1; then compound 4; then compounds 2 and 3 (each within the scatter of the next).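

In this assay the place on the sulfonyl sulfur had so far shown no step beyond the scatter, but a 2.3-fold lower number from compound 2 to compound 4 (0.35 log units; beyond the scatter) shows that (5-(trifluoromethyl)pyridin-3-yl)amino in place of hydroxy does move the number there, if only modestly. The exchange of 5-(trifluoromethyl)pyridin-3-yl for phenyl on the sulfonamide nitrogen gives a 2.5-fold lower number from compound 3 to compound 4 (0.39 log units; beyond the scatter), so among these compounds the group carried on that nitrogen matters, and not merely the replacement of hydroxy by an arylamino group. No supporting measurement is available that would account for either step.

From the compounds shown here alone, whether the lower number of compound 4 follows the trifluoromethyl group or the ring nitrogen stays open, and a plain pyridin-3-yl group and a trifluoromethylphenyl group on the sulfonamide nitrogen would separate the two. Going by these compounds, it is also open whether a non-aromatic group on that nitrogen, such as a methyl or cyclopropyl group, would keep or lose this modest change in the same assay.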